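A few compounds are considered here, and "the series" means these few. Any claim that something is new, unique, unknown or untested is made for them only; others in the source may bear on it.

Compound 2 `CCC1=C(OC)C(CC)(CC)C(=O)C(C(=O)/C=C/c2ccc(C)cc2)=C1O` gives 1 ug/mL in a functional assay on KB cells (Homo sapiens) for cytotoxicity (on this read-out lower numbers stand for an effect already at smaller amounts and higher numbers for an effect only at larger amounts of compound), and compound 1 `CCC1=C(OC)C(CC)(CC)C(=O)C(C(=O)/C=C/c2ccccc2)=C1O` gives 1.2 ug/mL in the same read-out, so the two numbers lie within the scatter of each other and no order can be read between them. The next compound on the shared core is compound 3 `CCC1=C(OC)C(CC)(CC)C(=O)C(C(=O)/C=C/c2ccc(CC)cc2)=C1O`, still unmeasured. Its difference from compound 2 is methyl in place of hydrogen on a saturated chain carbon bound to an aromatic carbon and amounts to methyl to ethyl, or 4-methylphenyl to 4-ethylphenyl. Within the data shown here, the one measured step that bears on this is a 1.2-fold lower number from compound 1 to compound 2 (0.08 log units; within the scatter) and it stays within the scatter. That step is also methyl in place of hydrogen, but on an aromatic carbon rather than on a saturated chain carbon bound to an aromatic carbon, so it is a loose guide only. With two measured compounds, the data hold no step beyond the scatter for any change of this kind. In this assay the expected step of no change at the digits printed from compound 2 to compound 3 (within the scatter) therefore stays within the scatter, with no direction favoured. Compound 3 is estimated at 1 ug/mL (expected range 0.4 ug/mL to 2.5 ug/mL).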

Compound 3, concentration for half-maximal effect: 2.6 ug/mL
Compound 3: middle estimate off by 2.6-fold (0.41 log units), on the low side; measured number above the stated range.
By their numbers in this assay, from the lowest: compounds 2 and 1 (each within the scatter of the next); then compound 3.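

In this assay, among these compounds, the change from 4-methylphenyl to 4-ethylphenyl is the first to clear the scatter, with a 2.6-fold higher number from compound 2 to compound 3 (0.41 log units; beyond the scatter) as a modest step on a saturated chain carbon bound to an aromatic carbon. Set against the plain phenyl of compound 1, the 4-ethylphenyl group gives a 2.2-fold higher number from compound 1 to compound 3 (0.34 log units; beyond the scatter), also modest, while the 4-methylphenyl group left no readable change, so among these three compounds the number moves only once the group has grown to ethyl. No measurement at hand explains this shift.

Going by these compounds, a single ethyl compound gives one step and no trend, so whether a longer chain such as propyl or butyl would carry the number further up, hold it or bring it back remains open. Equally open, on these data alone, is how a branched group such as isopropyl, or a methoxy group or an amine on the same aromatic carbon, would compare with methyl and ethyl.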